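The source may report more compounds than this note shows. Statements on the series, on what has been measured and on what is new or still open speak of the compounds shown alone.

Measured compounds:
- Compound 2 `Cc1nnsc1CO/N=C/c1c(C)nn(C)c1Oc1ccc(F)cc1`. In a functional assay on PANC-1 cells (Homo sapiens) for inhibition, read by MTT assay, with a stated time of 48 h (on this read-out higher numbers stand for weaker inhibition and lower numbers for stronger inhibition), compound 2 gives > 50000 nM, a limit of the assay rather than a number.
- Compound 1 `Cc1nnsc1CO/N=C/c1c(C)nn(C)c1Oc1cccc(F)c1`. In this assay compound 1 gives > 50000 nM, likewise a limit.

Compound 2 therefore stands only at the limit; both values shown sit there (the limit of > 50000 nM in this assay, at which 2 of the 2 values shown sit), so compound 2 cannot be placed against compound 1 beyond that. Among the measured compounds shown here, the single measured step, a step that the two limits leave unreadable from compound 1 to compound 2, is left unreadable by the two limits.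

Compound 3 `Cc1nnsc1CO/N=C/c1c(C)nn(C)c1Oc1ccc(Br)cc1` differs from compound 2 by bromo in place of fluoro on an aromatic carbon of a six-membered aromatic ring of carbon only, para to a large group. For the measured compounds named here, no measured step bears on a fluoro-to-bromo exchange, and the one step measured gives no size at all. There is thus no basis for expecting a readable change in this assay; the expectation is that compound 3 also stays at the limit. Compound 3 is estimated at 50000 nM, within 15000 nM to 200000 nM. The step this implies, a number no higher from compound 2 to compound 3 (the limit leaves the size open), is an expectation only.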

Compound 3, half-maximal inhibitory concentration: 12800 nM
Estimate against measurement, compound 3: 3.9-fold (0.59 log units) above; measured number below the stated range.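

In this assay, among the compounds shown here, the aromatic carbon para to a large group proves responsive to the halogen it carries: bromo in place of fluoro gives an at least 3.9-fold lower number from compound 2 to compound 3 (0.59 log units; beyond the scatter), the only step with a readable lower bound at this position. The exchange of 3-fluorophenyl for 4-bromophenyl gives an at least 3.9-fold lower number from compound 1 to compound 3 (0.59 log units; beyond the scatter), but this step changes the halogen and its place together and does not separate the two. Both sizes remain lower bounds because the fluoro compounds yield no number: the limit of > 50000 nM in this assay, at which 2 of the 3 values shown sit.

From the compounds shown here alone, the step between the two fluoro compounds cannot be read, so the contribution of the fluoro position alone stays unknown. Going by these compounds, whether the change tracks the halogen itself stays open, as does what chloro, iodo or methoxy at the same carbon would give.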